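A few compounds are considered here, and "the series" means these few. Any claim that something is new, unique, unknown or untested is made for them only; others in the source may bear on it.

Of the compounds shown here, two that share one core have been measured in a functional assay on MDA-MB-231 cells (Homo sapiens) for cytotoxicity, read by MTT assay, with a stated time of 72 h; a higher number here means a weaker inhibitor, a lower number a stronger inhibitor. Compound 1 `COc1cc2c(Oc3ccc(NC(=O)c4nn(-c5ccc(Br)cc5)c(=O)c5ccccc45)cc3F)ccnc2cc1OCCCN1CCN(C)CC1` gives 1370 nM in this assay. Compound 2 `COc1cc2c(Oc3ccc(NC(=O)c4nn(-c5ccccc5F)c(=O)c5ccccc45)cc3F)ccnc2cc1OCCCN1CCCCC1` gives 910 nM in this assay; the gap between compound 2 and compound 1 lies within the usual scatter of repeated measurements, so the two cannot be told apart on these numbers. Compound 3 `COc1cc2c(Oc3ccc(NC(=O)c4nn(-c5ccc(Br)cc5)c(=O)c5ccccc45)cc3F)ccnc2cc1OCCCN1CCCCC1` has not yet been measured. It differs from compound 2 in one place: 4-bromophenyl in place of 2-fluorophenyl on an aromatic nitrogen. Compound 1 carries the same 4-bromophenyl group and gives 1370 nM in this assay, close to compound 2, which points to a step of modest size at most. The step from compound 2 to compound 3 is therefore expected to stay within the scatter, a 1.2-fold higher number from compound 2 to compound 3 (0.08 log units; within the scatter). Compound 3 is estimated at 1100 nM, with a range from 500 nM to 2500 nM.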

Compound 3, half-maximal inhibitory concentration: 1130 nM
The estimate for compound 3 lay 1.0-fold (0.01 log units) below the measured number; measured number inside the range.
By their numbers in this assay, from the lowest: compounds 2, 3 and 1 (each within the scatter of the next).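

In this assay, 4-bromophenyl in place of 2-fluorophenyl on the aromatic nitrogen gives a 1.2-fold higher number from compound 2 to compound 3 (0.09 log units; within the scatter) and so does not separate these two groups, even though both the halogen and its position on the phenyl ring differ. The chain can now be read on its own too: piperidin-1-yl in place of 4-methylpiperazin-1-yl gives a 1.2-fold lower number from compound 1 to compound 3 (0.08 log units; within the scatter) and leaves these two groups equally inseparable. Nothing available here offers an explanation for either result.

Still open, from the compounds shown here alone, is whether an unsubstituted phenyl, or a phenyl carrying an amine or a carboxylic acid, on the aromatic nitrogen would give a step beyond the scatter. The same question stands for morpholin-4-yl or a longer chain in place of the present amine and chain.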